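Shrinking the Amide Group of Compound 2

A few compounds are considered here, and "the series" means these few. Any claim that something is new, unique, unknown or untested is made for them only; others in the source may bear on it.

For the measured compounds named here, in an ADME assay on L02 cells (Homo sapiens) for antiproliferative activity, read by MTT assay, with a stated time of 48 h (a higher number here means a weaker inhibitor, a lower number a stronger inhibitor), compound 2 `CCOC(=O)C(CC(=O)OC)NC(=O)c1ccc(C(CC)(CC)c2ccc(OCCC(O)(CC)CC)c(C)c2)n1CC` gives 4280 nM, the only actual number so far. Compound 1 `CCn1c(C(=O)NCC#N)ccc1C(CC)(CC)c1ccc(OCCC(O)(CC)CC)c(C)c1` gives > 50000 nM, which is a limit of the assay. Compound 3 `CCn1c(C(=O)N(C)CC(=O)O)ccc1C(CC)(CC)c1ccc(OCCC(O)(CC)CC)c(C)c1` differs from compound 2 as follows: a group of 6 heavy atoms (3 carbon, 1 nitrogen, 2 oxygen; no ring) in place of a group of 12 heavy atoms (7 carbon, 1 nitrogen, 4 oxygen; no ring), on a carbonyl carbon. Going by the values given here, the single measured step, an at least 11-fold lower number from compound 1 to compound 2 (1.06 log units; beyond the scatter), came with the larger group on the amide-type nitrogen. The smaller (carboxymethyl)(methyl)amino group is therefore expected to move this assay back towards a higher number, and a large change is anticipated. The expected step is a 5.8-fold higher number from compound 2 to compound 3 (0.77 log units; beyond the scatter). Compound 3 is estimated at 25000 nM, with an expected range of 9000 nM to 70000 nM.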

Compound 3, half-maximal inhibitory concentration: 2150 nM
Compound 3: middle estimate off by 12-fold (1.07 log units), on the high side, outside the stated range (below it).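

With the much smaller (carboxymethyl)(methyl)amino group on the carbonyl carbon, this assay shows no loss: a 2.0-fold lower number from compound 2 to compound 3 (0.30 log units; within the scatter). The large group is therefore not needed for this level of activity, and size alone does not order these three compounds, as the change of group at this place also gives an at least 23-fold lower number from compound 1 to compound 3 (1.36 log units; beyond the scatter). That step starts from a limit, the one for compound 1: the limit of > 50000 nM in this assay, at which 1 of the 3 values shown sits.

From the compounds shown here alone, whether the carboxymethyl or the methyl matters more remains open. So does the effect of a primary amine or a longer alkyl chain on this carbonyl carbon.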